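Adding a Nitro Group: What Compound 3 Might Show

A few compounds are considered here, and "the series" means these few. Any claim that something is new, unique, unknown or untested is made for them only; others in the source may bear on it.

compound 1 `N#CN/C(=N\CCCCCCOc1ccccc1)Nc1ccncc1`: 52 nM
compound 2 `N#CN/C(=N\CCCCCCOc1cccc(Cl)c1)Nc1ccncc1`: 59 nM

In a functional assay on NCI-H460 cells (Homo sapiens) for antiproliferative activity (on this read-out higher numbers stand for weaker inhibition and lower numbers for stronger inhibition), compound 1 gives 52 nM, the lower of the two numbers shown, while compound 2 gives 59 nM. Among the compounds with values here, the only measured step, a 1.1-fold higher number from compound 1 to compound 2 (0.05 log units; within the scatter), is a substitution on the same aromatic ring and stays within the scatter. Compound 3 `N#CN/C(=N\CCCCCCOc1ccc([N+](=O)[O-])cc1)Nc1ccncc1` differs from compound 1 by nitro in place of hydrogen on an aromatic carbon. Within the data shown here, since the one comparable step was flat, no step beyond the scatter is expected in this assay. Compound 3 is therefore estimated at 60 nM, between 25 nM and 145 nM, which means an expected 1.2-fold higher number from compound 1 to compound 3 (0.06 log units; within the scatter).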

Compound 3, half-maximal inhibitory concentration: 590 nM
The estimate for compound 3 lay 9.8-fold (0.99 log units) below the measured number; the measured number lies above the stated range.
By their numbers in this assay, from the lowest: compounds 1 and 2 (each within the scatter of the next); then compound 3.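

In this assay the phenyl ring proves sensitive to substitution: nitro para to a large group gives an 11-fold higher number from compound 1 to compound 3 (1.05 log units; beyond the scatter) and so weakens inhibition, which compound 2 had not suggested. Changing 3-chlorophenyl to 4-nitrophenyl gives a 10-fold higher number from compound 2 to compound 3 (1.00 log units; beyond the scatter) as well, so chloro and nitro do not behave alike on this ring. Nothing available here accounts for the loss. Open, on these data alone, is whether the step belongs to nitro itself or to its place on the ring. An amine or a methoxy group in that same place, or nitro as 3-nitrophenyl, would separate the two.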